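Aryl Swap on the Triazole: Compound 3 to Compound 4

The source may hold more compounds than are shown below. What is called first, only, known or untested is meant among the compounds shown, and "the series" means these compounds.

The measured compounds and their numbers in a functional assay on HCT-116 cells (Homo sapiens) for cytotoxicity, read by MTT assay, with a stated time of 24 h; a lower number here means a stronger inhibitor, a higher number a weaker inhibitor:
compound 1 `COc1ccc(/C=C\C(=O)O)c(OCc2cn(-c3ccccc3)nn2)c1CC=C(C)C` gives 26000 nM
compound 2 `COc1ccc(/C=C\C(=O)O)c(OCc2cn(-c3cccc([N+](=O)[O-])c3)nn2)c1CC=C(C)C` gives 27300 nM
compound 3 `COc1ccc(/C=C\C(=O)O)c(OCc2cn(-c3ccccc3C#N)nn2)c1CC=C(C)C` gives 38300 nM

Compound 3 holds the highest of the three numbers in this assay, yet its separation from compound 2 and from compound 1 lies within the usual scatter, so no order among the three can be drawn. The step to compound 4 `COc1cccc(-n2cc(COc3c(/C=C\C(=O)O)ccc(OC)c3CC=C(C)C)nn2)c1` changes the phenyl on the aromatic nitrogen: 3-methoxyphenyl in place of 2-cyanophenyl on an aromatic nitrogen.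

Two earlier steps bear on this: the change a 1.1-fold higher number from compound 1 to compound 2 (0.02 log units; within the scatter) and the change a 1.4-fold higher number from compound 2 to compound 3 (0.15 log units; within the scatter), both within the scatter, as was a 1.5-fold higher number from compound 1 to compound 3 (0.17 log units; within the scatter). Altering the substituent on the phenyl attached to the triazole nitrogen has thus not moved the number beyond the scatter in any measured pair. The expectation for compound 4 is therefore no change beyond the scatter, a 1.3-fold lower number from compound 3 to compound 4 (0.11 log units; within the scatter). Compound 4 is expected to give about 30000 nM, in a range from 15000 nM to 60000 nM.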

Compound 4, half-maximal inhibitory concentration: 21600 nM
Beside the measured number, compound 4's estimate is 1.4-fold (0.14 log units) above it; the measured number falls inside the stated range.
By their numbers in this assay, from the lowest: compounds 4, 1, 2 and 3 (each within the scatter of the next).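

With a methoxy group, the substituents on the phenyl on the aromatic nitrogen now include an oxygen-bearing group alongside nitro and nitrile, and in this assay this change again leaves the number within the scatter. This holds for the exchange of 2-cyanophenyl for 3-methoxyphenyl (a 1.8-fold lower number from compound 3 to compound 4 (0.25 log units; within the scatter)), for methoxy in place of nitro (a 1.3-fold lower number from compound 2 to compound 4 (0.10 log units; within the scatter)) and for methoxy in place of hydrogen (a 1.2-fold lower number from compound 1 to compound 4 (0.08 log units; within the scatter)). No measurement is available that could explain this insensitivity.

From the compounds shown here alone, whether an amine or a carboxylic acid on this phenyl, or a longer chain on the aromatic nitrogen in place of the phenyl, would move the number beyond the scatter remains open. All four compounds also share the rest of the core, so what that remainder contributes to the number is open too.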